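The compounds below may be only part of what the source reports. "The series", "measured", "known", "first", "only" and "open" are said of these compounds alone.

Measured in a functional assay on MDA-MB-231 cells (Homo sapiens) for inhibition, read by MTT assay, with a stated time of 72 h; a higher number here means a weaker inhibitor, a lower number a stronger inhibitor:
- compound 1 `COc1ccccc1-c1csc2cnc(Nc3ccc(NC(=O)C4CCNCC4)cc3)nc12`: 1050 nM
- compound 2 `COc1ccccc1-c1csc2cnc(Nc3ccc(C(=O)NC4CCNCC4)c(C)c3)nc12`: 240 nM
- compound 3 `COc1ccccc1-c1csc2cnc(Nc3ccc(C(=O)NC4CCNCC4)cc3C)nc12`: 3240 nM

Compound 3 has the highest number of the three and is therefore the weakest inhibitor of the set. Its gaps to compound 1 and to compound 2 both lie beyond the usual scatter.

Compound 4 `COc1ccccc1-c1csc2cnc(Nc3ccc(C(=O)NC4CCNCC4)cc3F)nc12` differs from compound 3 in one place: fluoro in place of methyl on an aromatic carbon. This is fluoro in place of methyl on an aromatic carbon, ortho to a large group and meta to a (piperidin-4-yl)carbamoyl group. Among the measured compounds shown here, no two measured compounds differ in only one place, so the data give no direct size for this swap. Compound 2 at 240 nM and compound 3 at 3240 nM both carry a methyl yet lie far apart, so numbers among these close relatives can spread widely.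

For the measured compounds named here, with compound 3 at 3240 nM, the highest number so far, a modest move toward a lower number in this assay is expected, though a change within the scatter would be no surprise. The estimated step is a 2.0-fold lower number from compound 3 to compound 4 (0.31 log units; beyond the scatter). For compound 4 the expected value is 1600 nM, with an estimated range of 550 nM to 4500 nM.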

Compound 4, half-maximal inhibitory concentration: 1610 nM
Beside the measured number, compound 4's estimate is 1.0-fold (0.00 log units) below it; the range from low to high includes it.
By their numbers in this assay, from the lowest: compound 2; then compounds 1, 4 and 3 (each within the scatter of the next, the first and the last beyond it).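

In this assay, fluoro in place of methyl on this aromatic carbon, ortho to a large group and meta to a (piperidin-4-yl)carbamoyl group, gives a 2.0-fold lower number from compound 3 to compound 4 (0.30 log units; within the scatter). This is the first direct reading of a swap in one place among these compounds, which the earlier values could not supply, and it shows that the two groups cannot be told apart at this position in this assay. The size of the step therefore offers no ground for preferring either group here, and no measurement at hand gives a reason for the result.

The compounds shown leave open what chloro, methoxy, trifluoromethyl or plain hydrogen on this same carbon would give, so it remains unknown whether any group here can move the number beyond the scatter. They also leave open whether fluoro in place of methyl would give a step of similar size on the aromatic carbon that carries the methyl in compound 2 (240 nM), where the starting number is a different one.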